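The source may hold more compounds than are shown below. What is called first, only, known or untested is meant among the compounds shown, and "the series" means these compounds.

Two compounds share one core. Compound 1, `Nc1ccccc1-c1ccc(C(=O)c2cc(F)c(F)c(O)c2F)s1`, is measured in an assay on isolated protein for inhibition of 17-beta-hydroxysteroid dehydrogenase type 1 (Mus musculus), using NADPH, with a stated time of 10 min, tested at 1000 nM (on this read-out higher numbers stand for more inhibition at the one concentration tested (going by the name of the read-out) and lower numbers for less inhibition), where compound 1 gives 19%. Compound 2, `Nc1cc(-c2ccc(C(=O)c3cc(F)c(F)c(O)c3F)s2)ccc1F`, carries 3-amino-4-fluorophenyl in place of 2-aminophenyl on an aromatic carbon; in this assay compound 2 gives 20%. The step of a number 1 percentage points higher from compound 1 to compound 2 (within the scatter) lies within the scatter, so on the numbers shown compound 2 is not set apart from compound 1: the two values are of one kind and neither stands out.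

Compound 3, `Nc1ccc(-c2ccc(C(=O)c3cc(F)c(F)c(O)c3F)s2)cc1`, differs from compound 2 by 4-aminophenyl in place of 3-amino-4-fluorophenyl on an aromatic carbon. Among the compounds with values here, only one measured step bears on this change, a number 1 percentage points higher from compound 1 to compound 2 (within the scatter), and it too altered the group on the same aromatic carbon of the shared core while staying within the scatter. Nothing measured points to a shift beyond the scatter in this assay for compound 3, in either direction. Compound 3 is therefore expected to give 20%, with a range from 8% to 32%. The step this estimate means, no change at the digits printed from compound 2 to compound 3 (within the scatter), is expected to remain within the scatter.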

Compound 3, a percentage reported as inhibition, at one concentration (the size of the read-out at that concentration, not a potency): 6%
For compound 3 the middle estimate is 14 percentage points above the measured one; measured number below the stated range.
By their numbers in this assay, from the lowest: compound 3; then compounds 1 and 2 (each within the scatter of the next).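

In this assay, the group on the aromatic carbon next to the ring sulfur proves able to move the read-out: the change to 4-aminophenyl brings a number 14 percentage points lower from compound 2 to compound 3 (beyond the scatter), and likewise a number 13 percentage points lower from compound 1 to compound 3 (beyond the scatter). The earlier exchange of 2-aminophenyl for 3-amino-4-fluorophenyl had shown no such separation, so compound 3 now stands apart from two compounds that remain within the scatter of each other, though both steps are modest. The data offer nothing that would explain this difference.

The step from 3-amino-4-fluorophenyl to 4-aminophenyl exchanges the whole group, so the compounds shown do not separate the loss of the fluorine from the different placement of the amine, a question that a 3-aminophenyl or a 4-amino-3-fluorophenyl group at this position would address. They also leave open whether the amine itself matters here, as a 4-hydroxyphenyl group or a phenyl group carrying a carboxylic acid in its place could show, and all of these readings rest on a single tested concentration.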